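Trading a sulfur-bearing chain for 2-fluorophenyl

A few compounds are considered here, and "the series" means these few. Any claim that something is new, unique, unknown or untested is made for them only; others in the source may bear on it.

In an ADME assay on BHK cells (Mesocricetus auratus) for cytotoxicity, read by MTT assay, with a stated time of 96 h (a higher number here means that more compound is tolerated, a lower number that less compound is tolerated), compound 1 `FC(F)(F)c1cccc(NC(=S)Nc2ccccc2)c1` gives 41000 nM. Compound 2 `CSCCCNC(=S)Nc1cccc(C(F)(F)F)c1` gives > 100000 nM, which is a limit of the assay and not a number. Its standing therefore rests only on (the limit of > 100000 nM in this assay, at which 1 of the 2 values shown sits).

Compound 3 `Fc1ccccc1NC(=S)Nc1cccc(C(F)(F)F)c1` places 2-fluorophenyl in place of 3-(methylsulfanyl)propyl on an amide-type nitrogen. Like compound 1, it therefore carries a six-membered aromatic ring at this place, though compound 3 also has fluorine. Among the measured compounds shown here, the one measured step that bears on this change is an at least 2.4-fold higher number from compound 1 to compound 2 (0.38 log units; beyond the scatter), found when 3-(methylsulfanyl)propyl replaced phenyl. For the measured compounds named here, that step is beyond the scatter, but its true size is open, and no measured pair shows what the fluorine does. Reversing the direction of that step, a move to a lower number in this assay is expected, meaning that less compound would be tolerated. The estimated change is an at least 2.6-fold lower number from compound 2 to compound 3 (0.42 log units; beyond the scatter). For compound 3, the expected value is 38000 nM, with an estimated range from 14000 nM to 95000 nM.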

Compound 3, half-maximal cytotoxic concentration: 54000 nM
For compound 3 the middle estimate is 1.4-fold (0.15 log units) below the measured one; the measured number falls inside the stated range.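

Setting fluoro in place of hydrogen on an aromatic carbon gives, in this assay, a 1.3-fold higher number from compound 1 to compound 3 (0.12 log units; within the scatter), so this first measured pair bearing on the fluorine shows two compounds that cannot be told apart. Setting 2-fluorophenyl in place of 3-(methylsulfanyl)propyl on the amide-type nitrogen gives an at least 1.8-fold lower number from compound 2 to compound 3 (0.26 log units; that floor lies within the scatter), so the part of this step that can be secured does not clear the scatter, even though the move from the chain to the aromatic ring was expected to matter. That floor is all that can be read, and the true size of the step stays open, because compound 2 stands at a limit of the assay and not at a number: the limit of > 100000 nM in this assay, at which 1 of the 3 values shown sits.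

The compounds shown leave open whether the sulfur or simply the absence of an aromatic ring sets compound 2 apart, and a plain butyl chain of carbon only at this nitrogen would separate the two. They also leave open whether chlorine or a methoxy group in place of the fluoro would stay as close to compound 1 as compound 3 does.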